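Aryl swap on the carbamoyl nitrogen: hydroxy for chloro

The source may hold more compounds than are shown below. What is called first, only, known or untested is meant among the compounds shown, and "the series" means these compounds.

Within the data shown here, compound 3 `COc1cc(C2CC(c3cc4ccccc4o3)=NN2C(=O)Nc2ccc(Cl)cc2)ccc1O` gives the highest number of the three measured so far in a functional assay on microsomes from liver (Rattus norvegicus, strain Wistar) for inhibition, with a stated time of 15 min (a higher number here means a weaker inhibitor, a lower number a stronger inhibitor), at 121000000 nM. Compound 2 `COc1cc(C2CC(c3cc4ccccc4o3)=NN2C(=O)Nc2ccc(Br)cc2)ccc1O` gives 115000000 nM in this assay, and the pair sit only a 1.1-fold higher number from compound 2 to compound 3 (0.02 log units; within the scatter) apart, within the scatter. Compound 1 `COc1cc(C2CC(c3cc4ccccc4o3)=NN2C(=O)Nc2cccc(O)c2)ccc1O` gives 24000000 nM in this assay. The steps of a 4.8-fold higher number from compound 1 to compound 2 (0.68 log units; beyond the scatter) and a 5.0-fold higher number from compound 1 to compound 3 (0.70 log units; beyond the scatter) are both modest but beyond the scatter, so the hydroxyphenyl compound 1 stands clearly apart from the two halogenated analogues.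

Compound 4 `COc1cc(C2CC(c3cc4ccccc4o3)=NN2C(=O)Nc2ccc(O)cc2)ccc1O` differs from compound 3 by hydroxy in place of chloro on an aromatic carbon. The step from compound 1 to compound 3 is the one that bears most directly on this change, since it also trades a hydroxyphenyl for a chlorophenyl, though the hydroxy stands at a different place on that ring; the step from compound 2 to compound 3 adds that the two halogens are indistinguishable here. On that basis compound 4 is expected to move back toward compound 1, giving a lower number in this assay by about a 3.0-fold lower number from compound 3 to compound 4 (0.48 log units; beyond the scatter). Compound 4 is therefore estimated at 40000000 nM, with a range from 12000000 nM to 130000000 nM.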

Compound 4, half-maximal inhibitory concentration: 15000000 nM
Compound 4: the middle estimate sits 2.7-fold (0.43 log units) above what was measured; the measured number falls inside the stated range.
By their numbers in this assay, from the lowest: compounds 4 and 1 (each within the scatter of the next); then compounds 2 and 3 (each within the scatter of the next).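

At the position para to a large group on the carbamoyl aryl ring, the single-atom exchange of halogen for hydroxy is now seen directly: in this assay the step from chloro is an 8.1-fold lower number from compound 3 to compound 4 (0.91 log units; beyond the scatter) and the step from bromo is a 7.7-fold lower number from compound 2 to compound 4 (0.88 log units; beyond the scatter), so the earlier separation of compound 1 from the halogenated pair does not depend on hydroxy standing at another ring position. The comparison of the two hydroxyphenyl isomers gives a 1.6-fold lower number from compound 1 to compound 4 (0.20 log units; within the scatter) and stays within the scatter, so 4-hydroxyphenyl and 3-hydroxyphenyl cannot be told apart here, and among these four compounds the division follows hydroxy versus halogen rather than the place of the hydroxy. No supporting measurement is available to explain this division.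

From the compounds shown here alone, it remains open how an unsubstituted phenyl, a methoxy, an amine or a carboxylic acid at the same position would compare with the hydroxy and halogen compounds. All four compounds also share one core, so whether the hydroxy-for-halogen step carries over to a different core is unsettled.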